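Swapping the group on the amine nitrogen of a pyrazole core

This account rests on a few compounds, and the source may have more. Where it says the series, first, only, none or still open, it means among the compounds named here.

Measured compounds:
compound 1 `CCOC(=O)C1=C(N/C=N/c2nnc(S(N)(=O)=O)s2)Nc2[nH]nc(C)c2C1c1ccc(N(C)C)cc1`, 38100 nM
compound 2 `CCOC(=O)C1=C(N/N=C(/C(=O)Br)c2ccc(Br)cc2)Nc2[nH]nc(C)c2C1c1ccc(N(C)C)cc1`, 65000 nM

Both were tested in a functional assay on HepG2 cells (Homo sapiens) for inhibition, read by MTT assay, with a stated time of 48 h; on this read-out higher numbers stand for weaker inhibition and lower numbers for stronger inhibition. Compound 2 gives the highest of the two numbers, and its nearest neighbour is compound 1, with a 1.7-fold higher number from compound 1 to compound 2 (0.23 log units; within the scatter). The new compound 3 `CCOC(=O)C1=C(N/C=N/c2ccc([N+](=O)[O-])cc2)Nc2[nH]nc(C)c2C1c1ccc(N(C)C)cc1` differs from compound 2 at the same place: a group of 11 heavy atoms (7 carbon, 2 nitrogen, 2 oxygen; one six-membered aromatic ring of carbon only) in place of a group of 12 heavy atoms (8 carbon, 1 nitrogen, 1 oxygen, 2 bromine; one six-membered aromatic ring of carbon only), on an amine nitrogen. Among the measured compounds shown here, only one measured step touches this position, the one from compound 1 to compound 2, and it stayed within the scatter. On that basis compound 3 is expected to sit near compound 2, with a step of about a 1.4-fold lower number from compound 2 to compound 3 (0.16 log units; within the scatter), and an estimated 45000 nM, ranging from 15000 nM to 130000 nM.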

Compound 3, half-maximal inhibitory concentration: 50900 nM
Compound 3: the middle estimate sits 1.1-fold (0.05 log units) below what was measured, within the range that was stated.
By their numbers in this assay, from the lowest: compounds 1, 3 and 2 (each within the scatter of the next).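

In this assay a third, quite different group on the amine nitrogen again stays within the scatter of both earlier compounds (a 1.3-fold lower number from compound 2 to compound 3 (0.11 log units; within the scatter); a 1.3-fold higher number from compound 1 to compound 3 (0.13 log units; within the scatter)). The 4-nitrophenyl group therefore cannot be told apart from 5-sulfamoyl-1,3,4-thiadiazol-2-yl here, so three unlike groups now give no readable difference at this position. No measured evidence offers an explanation for this. Still open, on these data alone, is whether an amine or a carboxylic acid on this nitrogen would give a number beyond the scatter. Also open, as far as these compounds go, is whether changes elsewhere on the shared core would do so.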